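Hydroxyphenyl in Place of Dichlorophenyl on a Shared Core

The compounds below may be only part of what the source reports. "The series", "measured", "known", "first", "only" and "open" are said of these compounds alone.

Three compounds were measured in an assay on cells for displacement of a labelled ligand from adenosine receptor A1 (Homo sapiens), read by scintillation counting and radioligand binding, with a stated time of 60 min; on this read-out higher numbers stand for weaker inhibition and lower numbers for stronger inhibition:

Compound 1 `CN1CCN(c2nc(-c3ccc(Cl)c(Cl)c3)nc3[nH]cnc23)CC1`: 631 nM
Compound 2 `Oc1cccc(-c2nc(N3CCCCC3)c3nc[nH]c3n2)c1`: 10 nM
Compound 3 `CN1CCN(c2nc(-c3ccccc3O)nc3c2ncn3C)CC1`: 631 nM

Compound 1 stands level with compound 3 at the digits shown, the two together giving the highest numbers of the three; the gap between them lies within the scatter of repeated measurements. Compound 2 is furthest from compound 1, with a much lower number that lies beyond the scatter. No pair of these compounds differs in only one place, so no single step between measured compounds can be read off.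

Compound 4 `CN1CCN(c2nc(-c3ccc(O)cc3)nc3[nH]cnc23)CC1` has not yet been measured in this assay. It follows from compound 1 by one change: 4-hydroxyphenyl in place of 3,4-dichlorophenyl on an aromatic carbon. Compound 2, which carries a hydroxyphenyl on the same core, gives 10 nM, though it also carries a different amine. Compound 4 is therefore expected to show a moderate step to a lower number, a 2.5-fold lower number from compound 1 to compound 4 (0.40 log units; beyond the scatter), with the estimate for compound 4 put at 250 nM, within a range from 60 nM to 1000 nM.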

Compound 4, inhibition constant: 398 nM
Beside the measured number, compound 4's estimate is 1.6-fold (0.20 log units) below it, and the stated range covers the measured number.
By their numbers in this assay, from the lowest: compound 2; then compounds 4, 1 and 3 (each within the scatter of the next).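

In this assay, 4-hydroxyphenyl in place of 3,4-dichlorophenyl on the aromatic carbon between two ring nitrogen atoms gives a 1.6-fold lower number from compound 1 to compound 4 (0.20 log units; within the scatter). With the 4-methylpiperazin-1-yl group and the rest of the shared core held fixed, this exchange of a group without hydrogen-bond donors for one that carries a donor therefore leaves the read-out within the usual scatter. Nothing among the available data offers an explanation for this result.

Steps linking compound 2 or compound 3 to compound 1 or compound 4 cannot be read, since each of those pairs differs in more than one place. Also open, going by these compounds, is how this position would respond to a methoxy group, an amine or a carboxylic acid in place of the hydroxyl of the 4-hydroxyphenyl.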